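Benzamide in Place of Propoxymethyl Amide on a Shared Core

The source may hold more compounds than are shown below. What is called first, only, known or untested is meant among the compounds shown, and "the series" means these compounds.

Measured in an ADME assay on Vero cells (Chlorocebus sabaeus) for cytotoxicity, read by resazurin assay, with a stated time of 3 days; a lower number here means a stronger inhibitor, a higher number a weaker inhibitor:
compound 1 `CCOCCOC(=O)Nc1cc2nc(C3CCCCC3)[nH]c2cc1N(C)C`: > 100 ug/mL
compound 2 `CN(C)c1cc2[nH]c(C3CCCCC3)nc2cc1NC(=O)OCc1ccccc1`: > 100 ug/mL
compound 3 `CCCOCC(=O)Nc1cc2nc(C3CCCCC3)[nH]c2cc1N(C)C`: < 50 ug/mL

In this assay compound 3 reaches only a limit, < 50 ug/mL. The value of compound 1, > 100 ug/mL, is likewise a limit. Compound 2 too gives only the limit > 100 ug/mL. Compound 3 thus sits at the limit of < 50 ug/mL in this assay, at which 1 of the 3 values shown sits, while the other two sit at the limit of > 100 ug/mL in this assay, at which 2 of the 3 values shown sit. Compound 4 `CN(C)c1cc2[nH]c(C3CCCCC3)nc2cc1NC(=O)c1ccccc1` differs from compound 3 in phenyl in place of propoxymethyl on a carbonyl carbon. The measured steps that bear on this are an at least 2.0-fold lower number from compound 2 to compound 3 (0.30 log units; that floor lies within the scatter) and an at least 2.0-fold lower number from compound 1 to compound 3 (0.30 log units; that floor lies within the scatter), each set by limits, together with a step that the two limits leave unreadable from compound 1 to compound 2. Returning an aromatic ring to the carbonyl carbon, a modestly higher number is expected, an at least 1.2-fold higher number from compound 3 to compound 4 (0.07 log units; that floor lies within the scatter). Compound 4 is therefore estimated at 60 ug/mL, between 20 ug/mL and 150 ug/mL.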

Compound 4, half-maximal inhibitory concentration: > 100 ug/mL
Compound 4: only a limit was reported; the forecaster's own chance of this, stated with the estimate: 45%; at least 1.6-fold (0.22 log units) between middle value and limit.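

Phenyl on the carbonyl carbon gives an at least 2.0-fold higher number from compound 3 to compound 4 (0.30 log units; that floor lies within the scatter) in this assay. Of the four groups shown at this place, only propoxymethyl, in compound 3, sits at the lower limit: the limit of < 50 ug/mL in this assay, at which 1 of the 4 values shown sits. The steps to compound 4 from compound 1 and from compound 2 cannot be read, as each joins two limits.

Going by these compounds, how far compounds 1, 2 and 4 truly differ stays open. Also open, on these data alone, is whether an amine, a carboxylic acid or a longer chain on this carbonyl carbon would read like compound 3 or like compound 4.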